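This account rests on a few compounds, and the source may have more. Where it says the series, first, only, none or still open, it means among the compounds named here.

In a functional assay on HT-29 cells (Homo sapiens) for antiproliferative activity, read by sulforhodamine B assay, with a stated time of 72 h (a lower number here means a stronger inhibitor, a higher number a weaker inhibitor), compound 1 `CCCCCCCCc1ccc(CCC(CO)(CO)NC(C)=O)c2ccccc12` gives 36500 nM and compound 2 `CCCCCCCCc1ccc(CCC(CO)(CO)NC(=O)CCCCCCC)c2ccccc12` gives 22000 nM. For the measured compounds named here, these two values lie within the scatter of each other, so compound 1 stands level with the only other compound measured. Compound 3 `CCCCCCCCc1ccc(C(O)CC(CO)(CO)NC(C)=O)c2ccccc12` alters compound 1 in one place: hydroxy in place of hydrogen on a saturated chain carbon bound to an aromatic carbon and a saturated chain carbon. Going by the values given here, the only measured step, a 1.7-fold lower number from compound 1 to compound 2 (0.22 log units; within the scatter), involves hexyl at a different place, so it is indirect evidence, and no measured step tests hydroxy. No change beyond the scatter is expected in either direction. The estimated step is a 1.2-fold lower number from compound 1 to compound 3 (0.09 log units; within the scatter). For compound 3, the expected value is 30000 nM, with an estimated range of 12000 nM to 70000 nM.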

Compound 3, half-maximal inhibitory concentration: 77900 nM
Compound 3: middle estimate off by 2.6-fold (0.41 log units), on the low side, and the stated range ends below it.
By their numbers in this assay, from the lowest: compounds 2 and 1 (each within the scatter of the next); then compound 3.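

Hydroxy in place of hydrogen on a saturated chain carbon bound to an aromatic carbon and a saturated chain carbon is the first change shown to pass the scatter: in this assay the change gives a 2.1-fold higher number from compound 1 to compound 3 (0.33 log units; beyond the scatter) as a modest loss of strength. This position therefore responds to substitution, and hydroxy there does not improve on hydrogen. Nothing available explains the shift. As far as these compounds go, a methoxy group, a fluorine atom or an amine on this carbon remains open. So does whether hydroxy has the same effect alongside the longer chain of compound 2.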